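The source may hold more compounds than are shown below. What is called first, only, known or untested is meant among the compounds shown, and "the series" means these compounds.

Measured compounds in a functional assay on MCF7 cells (Homo sapiens) for inhibition, read by MTT assay, with a stated time of 48 h; a higher number here means a weaker inhibitor, a lower number a stronger inhibitor:

compound 1 `COc1ccc(/C=C/c2cc(OC)cc(OC)c2/C=C/C(=O)NC2CC2)cc1` gives 3940 nM
compound 2 `CCCCNC(=O)/C=C/c1c(/C=C/c2ccc(OC)cc2)cc(OC)cc1OC` gives 1330 nM
compound 3 `COc1ccc(/C=C/c2cc(OC)cc(OC)c2/C=C/C(=O)N2CCC(c3ccccc3)CC2)cc1` gives 4230 nM

Compound 2 stands lowest of the three numbers in this assay. The step of a 3.0-fold lower number from compound 1 to compound 2 (0.47 log units; beyond the scatter) and the step of a 3.2-fold higher number from compound 2 to compound 3 (0.50 log units; beyond the scatter) both lie beyond the scatter, whereas the step of a 1.1-fold higher number from compound 1 to compound 3 (0.03 log units; within the scatter) lies within it, so compound 1 and compound 3 cannot be ordered against each other.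

Compound 4 `CCCCCCNC(=O)/C=C/c1c(/C=C/c2ccc(OC)cc2)cc(OC)cc1OC` differs from compound 2 by ethyl in place of hydrogen on a saturated chain carbon, four bonds along the chain from an amide-type nitrogen. Of the measured steps, only a 3.0-fold lower number from compound 1 to compound 2 (0.47 log units; beyond the scatter) concerns the open chain on the amide-type nitrogen, and it shows that butyl in place of cyclopropyl gave the lowest number of the series; the other two steps replace the whole amine with 4-phenylpiperidin-1-yl and say nothing about chain length. Among the measured compounds shown here, no measured pair lengthens an existing chain. The expectation for this assay is therefore a step of a 1.2-fold lower number from compound 2 to compound 4 (0.08 log units; within the scatter) that stays near compound 2, with the direction open. Compound 4 is estimated at 1100 nM, within a range of 400 nM to 3000 nM.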

Compound 4, half-maximal inhibitory concentration: 5530 nM
The estimate for compound 4 lay 5.0-fold (0.70 log units) below the measured number; the whole stated range lies below it.
By their numbers in this assay, from the lowest: compound 2; then compounds 1, 3 and 4 (each within the scatter of the next).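

In this assay, the open chain on the amide-type nitrogen turns out to be sensitive to length: ethyl in place of hydrogen, four bonds along the chain from that nitrogen, turns butyl into hexyl and gives a clear loss (a 4.2-fold higher number from compound 2 to compound 4 (0.62 log units; beyond the scatter)), so the low number of compound 2 does not carry over to the longer chain. The hexyl amide cannot be told apart from the cyclopropyl amide (a 1.4-fold higher number from compound 1 to compound 4 (0.15 log units; within the scatter)) or from the 4-phenylpiperidin-1-yl amide (a 1.3-fold higher number from compound 3 to compound 4 (0.12 log units; within the scatter)), which leaves compound 2 alone at the low end of the four. No measurement on hand bears on why chain length matters here.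

Still open, on these data alone, is whether a pentyl or propyl chain would keep the low number of compound 2, and whether an octyl chain would raise the number further. As far as these compounds go, it is also open how a hydroxyl or an amine at the end of the butyl chain would read in this assay.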